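A few compounds are considered here, and "the series" means these few. Any claim that something is new, unique, unknown or untested is made for them only; others in the source may bear on it.

Three compounds were measured in a functional assay on Hs-578T cells (Homo sapiens) for inhibition, read by sulforhodamine B assay, with a stated time of 48 h, tested at 10 uM; on this read-out lower numbers stand for a stronger effect and higher numbers for a weaker effect at the one concentration tested: compound 1 `O=C(Nc1cccc(-n2cc(-c3ccncc3)c(-c3cc(O)cc(Cl)c3)n2)c1)Nc1ccc(Cl)c(C(F)(F)F)c1` gives 21.7%, compound 2 `COc1cc(Cl)cc(-c2nn(-c3cccc(NC(=O)Nc4ccc(Cl)c(C(F)(F)F)c4)c3)cc2-c2ccncc2)c1` gives 14.6%, and compound 3 `O=C(Nc1cccc(-n2cc(-c3ccncc3)c(-c3cc(O)cc(Cl)c3)n2)c1)c1cc(C(F)(F)F)cc(C(F)(F)F)c1` gives 65.9%.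

Compound 1 and compound 2 differ in one place, (methyl in place of hydrogen on an oxygen on an aromatic ring), and that change produced the step of a number 7.1 percentage points lower from compound 1 to compound 2 (within the scatter). Compound 3 carries a different core from compound 1; the difference between the two cores is not broken down here. Compound 4 `COc1cc(Cl)cc(-c2nn(-c3cccc(NC(=O)c4cc(C(F)(F)F)cc(C(F)(F)F)c4)c3)cc2-c2ccncc2)c1` has not yet been measured and relates to compound 3 exactly as compound 2 relates to compound 1: the change is methyl in place of hydrogen on an oxygen on an aromatic ring, at a place described in the same words, so it is the same change. For compound 4 a step of about a number 6.9 percentage points lower from compound 3 to compound 4 (within the scatter) is expected in this assay. This expectation rests on the earlier step of a number 7.1 percentage points lower from compound 1 to compound 2 (within the scatter), which was small. Compound 4 is therefore estimated at 59% in this assay. The likely range for compound 4 is expected to run from 45% to 75%.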

Compound 4, a percentage reported as activity, at one concentration (the size of the read-out at that concentration, not a potency): 81.1%
Beside the measured number, compound 4's estimate is 22.1 percentage points below it; measured number outside the range, above it.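

In this assay, replacing hydroxy with methoxy gives a number 15.2 percentage points higher from compound 3 to compound 4 (beyond the scatter), a weaker effect at the one concentration tested. The change therefore did not carry over unchanged from one core to the other: the same change on two cores in this assay, a number 7.1 percentage points lower (within the scatter) from compound 1 to compound 2 and a number 15.2 percentage points higher (beyond the scatter) from compound 3 to compound 4, 22.3 percentage points apart, beyond the scatter of two such steps

This shows that the size and direction of the step differed between these two pairs, but it does not show which part of the cores accounts for that, and two pairs set no rule for other cores in the series. The compounds shown leave open how an ethyl group or a longer chain on that oxygen, or an amine in place of the hydroxy, would behave on either core. They also leave open whether the gap between the two steps would persist at other concentrations.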